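A few compounds are considered here, and "the series" means these few. Any claim that something is new, unique, unknown or untested is made for them only; others in the source may bear on it.

Measured so far in a functional assay on QGY-7703 cells (Homo sapiens) for cytotoxicity, read by MTT assay, with a stated time of 24 h; on this read-out higher numbers stand for weaker inhibition and lower numbers for stronger inhibition:
- compound 1 `O=C1/C(=C/c2cccnc2)CN(S(=O)(=O)c2ccc([N+](=O)[O-])cc2)C/C1=C\c1ccccc1F` gives 5600 nM
- compound 2 `O=C1/C(=C/c2ccncc2)CN(S(=O)(=O)c2ccc([N+](=O)[O-])cc2)C/C1=C\c1ccccc1F` gives 8800 nM

Within the data shown here, the single measured step is a 1.6-fold higher number from compound 1 to compound 2 (0.20 log units; within the scatter) and it leaves compound 2 level with compound 1. Compound 3 `CC(=O)Nc1ccc(S(=O)(=O)N2C/C(=C\c3ccncc3)C(=O)/C(=C/c3ccccc3F)C2)cc1` carries acetamido in place of nitro on an aromatic carbon in the change from 4-nitrophenyl to 4-acetamidophenyl. Among the measured compounds shown here, the measured step swaps pyridin-3-yl for pyridin-4-yl elsewhere, so no measured step bears on this change, and no shift beyond the scatter is expected. The estimate rests on compound 2 at 8800 nM alone. The expected result is a 1.1-fold lower number from compound 2 to compound 3 (0.04 log units; within the scatter) with no clear direction. For compound 3 the estimate is 8000 nM with an expected range from 2500 nM to 25000 nM around it.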

Compound 3, half-maximal inhibitory concentration: 13700 nM
Estimate against measurement, compound 3: 1.7-fold (0.23 log units) below; measured number inside the range.
By their numbers in this assay, from the lowest: compounds 1, 2 and 3 (each within the scatter of the next, the first and the last beyond it).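

In this assay, the change from 4-nitrophenyl to 4-acetamidophenyl gives a 1.6-fold higher number from compound 2 to compound 3 (0.19 log units; within the scatter). Among these compounds, this is the first reading at this position, which the pyridine swap left untouched, and acetamido, which carries a hydrogen-bond donor that nitro lacks, stays within the scatter of nitro. From the compounds shown here alone, whether an amine or a carboxylic acid at this position would read differently remains open, as does whether the same change holds with pyridin-3-yl in place of pyridin-4-yl. Nothing available explains this result.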